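Saturating the Acid Chain in a Cyclobutyl Prostanoid Series

The source may hold more compounds than are shown below. What is called first, only, known or untested is meant among the compounds shown, and "the series" means these compounds.

Of the compounds shown here, three have been tested in a functional assay on the whole organism (strain Hartley) for inhibition, with Cavia porcellus as the target, with stated times of 15 min and 2 min; a higher number here means that more compound is needed for the effect, a lower number that less compound is needed. Compound 1 `CCCCC1([C@@H](O)/C=C/C2[C@H](O)CC(=O)[C@@H]2CCCCCCC(=O)O)CCC1` gives 0.03 mg/kg, compound 2 `CCCCC1([C@@H](O)/C=C/C2CCC(=O)[C@@H]2CCCCCCC(=O)OCC)CCC1` gives 0.00206 mg/kg, and compound 3 `CCCCC1([C@H](O)/C=C/C2CCC(=O)[C@@H]2C/C=C\CCCC(=O)O)CCC1` gives 0.0242 mg/kg. Compound 3 thus has the second highest of the three numbers: its number and that of compound 1 lie within the scatter of each other, while compound 2 sits well below it, beyond the scatter.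

Compound 4 `CCCCC1([C@H](O)/C=C/C2CCC(=O)[C@@H]2CCCCCCC(=O)O)CCC1` has not yet been measured. It differs from compound 3 in one place: 5-carboxypentyl in place of 5-carboxypent-1-en-1-yl on a saturated chain carbon bound to a saturated ring carbon. For the measured compounds named here, no pair of measured compounds shows this change alone, so its size is open. The saturated chain is shared with compound 1 and compound 2, whose numbers bracket compound 3. A step from compound 3 to compound 4 of a 1.3-fold lower number from compound 3 to compound 4 (0.13 log units; within the scatter) is expected, most likely within the scatter. Compound 4 is therefore estimated at 0.018 mg/kg, with a range of 0.005 mg/kg to 0.06 mg/kg.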

Compound 4, dose for half-maximal effect: 47.8 mg/kg
Compound 4: middle estimate off by 2700-fold (3.42 log units), on the low side; the whole stated range lies below it.
By their numbers in this assay, from the lowest: compound 2; then compounds 3 and 1 (each within the scatter of the next); then compound 4.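

This position does not tolerate the change: in this assay, swapping 5-carboxypent-1-en-1-yl for 5-carboxypentyl, which has the same heavy-atom count but one double bond fewer, gives a 2000-fold higher number from compound 3 to compound 4 (3.30 log units; beyond the scatter). For the compounds shown here, a single double bond in this chain thus separates a compound needing very little from one needing far more, which no earlier pair could show. Nothing available explains this large step.

From the compounds shown here alone, it remains open whether an alkyne in the same chain would behave like compound 3 or like compound 4. Whether the double bond has as large an effect on the cores of compound 1 and compound 2 is also unknown.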